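A few compounds are considered here, and "the series" means these few. Any claim that something is new, unique, unknown or untested is made for them only; others in the source may bear on it.

Measured in a toxicity assay on Huh-7.5 cells (Homo sapiens) for cytotoxicity, read by MTT assay, with a stated time of 96 h; on this read-out higher numbers stand for lower toxicity in this test and lower numbers for higher toxicity in this test:
Compound 1 `CN1CCCN(c2ccc(C#N)c(CN3CCN([C@@H](c4ccccc4)c4ccc(Cl)cc4)CC3)c2)CC1`: > 20000 nM (a limit of the assay, not a number)
Compound 2 `CN1CCCN(c2ccc(C#N)c(CN3CCN(C(c4ccccc4)c4ccc(Cl)cc4)CC3)c2)CC1`: 7340 nM
Compound 3 `CN(C)CCN(C)CCN(C)c1ccc(C#N)c(CN2CCN(C(c3ccccc3)c3ccc(Cl)cc3)CC2)c1`: 6340 nM

Among the compounds with values here, compound 2 stands level with the only other exact number, as the step of a 1.2-fold lower number from compound 2 to compound 3 (0.06 log units; within the scatter) shows. Compound 4 `CN1CCCN(c2ccc(C(F)(F)F)c(CN3CCN(C(c4ccccc4)c4ccc(Cl)cc4)CC3)c2)CC1` has trifluoromethyl in place of cyano on an aromatic carbon. Within the data shown here, no measured step touches that place. The step of an at least 2.7-fold lower number from compound 1 to compound 2 (0.43 log units; beyond the scatter) concerns only drawn configuration, (the fact that one of compounds 1 and 2 is drawn with a defined configuration and the other without, at the place where they differ), and ends in the limit of > 20000 nM in this assay, at which 1 of the 3 values shown sits, so it offers little guidance. The step of a 1.2-fold lower number from compound 2 to compound 3 (0.06 log units; within the scatter) replaces another group and stays small, so it is the only, indirect, guide. No change beyond the scatter is therefore expected, and the expected step is a 1.1-fold lower number from compound 2 to compound 4 (0.05 log units; within the scatter). Compound 4 is estimated at 6500 nM, with an expected range of 3000 nM to 15000 nM.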

Compound 4, half-maximal cytotoxic concentration: 1290 nM
For compound 4 the middle estimate is 5.0-fold (0.70 log units) above the measured one, outside the stated range (below it).
By their numbers in this assay, from the lowest: compound 4; then compounds 3 and 2 (each within the scatter of the next). At a limit, above all of these: compound 1.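

In this assay the aromatic carbon para to the 4-methyl-1,4-diazepan-1-yl group proves sensitive to its substituent: trifluoromethyl in place of cyano gives a 5.7-fold lower number from compound 2 to compound 4 (0.76 log units; beyond the scatter) and so higher toxicity in this test. Within the data shown here, the earlier compounds held no change at this place, and their one exact step a 1.2-fold lower number from compound 2 to compound 3 (0.06 log units; within the scatter) lay elsewhere. Nothing measured here explains the size of this new step. Open, as far as these compounds go, is how other groups on this carbon, such as a methyl group, a primary amide or a carboxylic acid, would read. Also open, from the compounds shown here alone, is whether the same exchange would carry over to the open amine chain of compound 3.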